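Swapping an alkyl amide for an aryl amide

This account rests on a few compounds, and the source may have more. Where it says the series, first, only, none or still open, it means among the compounds named here.

In an ADME assay on HCT-116 cells (Homo sapiens) for cytotoxicity, read by MTT assay, with a stated time of 72 h (on this read-out higher numbers stand for weaker inhibition and lower numbers for stronger inhibition), compound 1 `O=C(NCC1CCCCC1)c1cccc(/C=C2\CC(=O)N(c3ccccc3)C2=O)c1` gives only a limit, > 100000 nM, and not a number. Compound 4 `COc1ccc(OC)c(NC(=O)c2cccc(/C=C3\CC(=O)N(c4ccccc4)C3=O)c2)c1` is not yet measured; it differs from compound 1 in one place, (2,5-dimethoxyphenyl in place of cyclohexylmethyl on an amide-type nitrogen). The nearest measured comparison is the pair of compound 2 `CCCCCN1C(=O)C/C(=C\c2cccc(C(=O)NCCCC)c2)C1=O` and compound 3 `CCCCCN1C(=O)C/C(=C\c2cccc(C(=O)Nc3cccc(CC)c3)c2)C1=O`, which change an alkyl group on the same kind of nitrogen for an aromatic one. Compound 2 gives only a limit, > 100000 nM. Compound 3 gives 75300 nM. Together these read as an at least 1.3-fold lower number from compound 2 to compound 3 (0.12 log units; that floor lies within the scatter), which is a change inside the scatter, and the limit of > 100000 nM in this assay, at which 2 of the 3 values shown sit, shows how little room the numbers give. By analogy, compound 4 is expected to sit close to compound 1, with a step of an at least 1.1-fold lower number from compound 1 to compound 4 (0.04 log units; that floor lies within the scatter). The estimate for compound 4 in this assay is therefore 90000 nM, with a range from 40000 nM to 300000 nM, and a fair chance that only a limit is reported again.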

Compound 4, half-maximal inhibitory concentration: > 100000 nM
Compound 4 was reported as a limit (the forecaster's own chance of this, stated with the estimate: 55%); middle value at least 1.1-fold (0.04 log units) away from the limit.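

In this assay compound 1 and compound 4 each give a limit and not a number, so no step can be read between them: the limit of > 100000 nM in this assay, at which 3 of the 4 values shown sit. As far as these compounds go, whether 2,5-dimethoxyphenyl and cyclohexylmethyl on an amide-type nitrogen differ at all in this read-out stays open.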